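Working notes toward compound 4 in a small series

The source may hold more compounds than are shown below. What is called first, only, known or untested is meant among the compounds shown, and "the series" means these compounds.

Measured compounds in a functional assay on HCT-116 cells (Homo sapiens) for antiproliferative activity, read by MTT assay, with a stated time of 24 h; a lower number here means a stronger inhibitor, a higher number a weaker inhibitor:
- Compound 1, `COc1cccc(/C=C/C(=O)c2ccc(OC)c3c2OC(C)(C)C=C3)c1`, gives > 10000 nM, which is a limit of the assay.
- Compound 2, `COc1ccc(C(=O)/C=C/c2ccc(N3CCCC3)cc2)c2c1C=CC(C)(C)O2`, gives 8590 nM.
- Compound 3, `COc1ccc(C(=O)/C=C/c2ccsc2)c2c1C=CC(C)(C)O2`, gives > 10000 nM, again a limit of the assay.

Compound 3 thus stands at the limit in this assay, with no number of its own. Compound 1 sits at the same limit: the limit of > 10000 nM in this assay, at which 2 of the 3 values shown sit. Only compound 2 carries a number among the three values shown. Going by the values given here, the one measured step between compounds that differ in a single place is a step that the two limits leave unreadable from compound 1 to compound 3. Both of its ends are limits. Its size cannot be read.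

Compound 4, `COc1ccc(C(=O)/C=C/c2ccc(O)cc2)c2c1C=CC(C)(C)O2`, is not yet measured. It differs from compound 3 as follows: 4-hydroxyphenyl in place of thiophen-3-yl on a double-bonded chain carbon bound to a double-bonded chain carbon. Among the compounds with values here, no measured step bears directly on this change. The step from compound 1 to compound 3 is unreadable, and compound 2 differs from compound 4 in another place, so only its value can be set beside the question.

With compound 3 at the limit, no step beyond the scatter is expected in this assay in either direction. The estimated step that the limit leaves unreadable from compound 3 to compound 4 is therefore expected to carry a wide range. Compound 4 is expected at 12000 nM, between 4000 nM and 40000 nM.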

Compound 4, half-maximal inhibitory concentration: > 10000 nM
Compound 4 ended at the assay's limit; the forecaster's own chance of this, stated with the estimate: 60%; the middle value is on the limit's open side.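

In this assay compound 4 gives > 10000 nM, a limit of the assay, so a hydrogen-bond donor on the 4-hydroxyphenyl group yields no number at this position. This position has now carried 3-methoxyphenyl, thiophen-3-yl and 4-hydroxyphenyl, and the steps among compounds 1, 3 and 4 cannot be read, with all three compounds at the same limit: the limit of > 10000 nM in this assay, at which 3 of the 4 values shown sit.

Going by these compounds alone, the one step that can be read, hydroxy in place of pyrrolidin-1-yl on an aromatic carbon, is an at least 1.1-fold higher number from compound 2 to compound 4 (0.06 log units; that floor lies within the scatter), so the limit alone does not separate the two groups beyond the usual scatter.

On these data alone, how far compounds 1, 3 and 4 lie past the limit stays open, and with it whether the pyrrolidin-1-yl group of compound 2 contributes anything real to its value. Also open, as far as these compounds go, is how a morpholine, a carboxylic acid or a longer chain would read on that aromatic carbon, and whether any of them would bring a measurable number in this assay.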